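The source may report more compounds than this note shows. Statements on the series, on what has been measured and on what is new or still open speak of the compounds shown alone.

Measured in a functional assay on EKVX cells (Homo sapiens) for cytotoxicity, read by sulforhodamine B assay, with a stated time of 48 h; a higher number here means that more compound is tolerated, a lower number that less compound is tolerated:

Compound 1, `ClCc1ccc(Cn2cnc3c(Cl)ncnc32)cc1`, gives 38900 nM.
Compound 2, `Nc1nc(Cl)c2ncn(Cc3ccc(CCl)cc3)c2n1`, gives 28200 nM.
Compound 3, `ClCc1ccccc1Cn1cnc2c(Cl)ncnc21`, gives 37200 nM.

Compound 4, `Nc1nc(Cl)c2ncn(Cc3ccccc3CCl)c2n1`, has not yet been measured. It arises from compound 3 by the change (amino in place of hydrogen on an aromatic carbon). The same change has already been made once, from compound 1 to compound 2, as amino in place of hydrogen on an aromatic carbon, and there it gave a 1.4-fold lower number from compound 1 to compound 2 (0.14 log units; within the scatter). The difference between the core of compound 1 and the core of compound 3 is not broken down here; their values in this assay lie within the scatter of each other, so nothing can be said about an order between them. Since the amino group is entering at the same place on the same kind of ring, the step from compound 3 to compound 4 is expected to be small, about a 1.3-fold lower number from compound 3 to compound 4 (0.12 log units; within the scatter). Compound 4 is therefore estimated at 28000 nM, most likely between 14000 nM and 56000 nM.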

Compound 4, concentration lethal to 50% of the cells: 60300 nM
Compound 4: the middle estimate sits 2.2-fold (0.33 log units) below what was measured; the whole stated range lies below it.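

Putting the amino group on the core of compound 3 gives a 1.6-fold higher number from compound 3 to compound 4 (0.21 log units; within the scatter) in this assay, so this step alone shows no real effect. The same change on the two cores can be compared directly, and the two steps do not differ beyond the scatter: the same change on two cores in this assay, a 1.4-fold lower number (0.14 log units; within the scatter) from compound 1 to compound 2 and a 1.6-fold higher number (0.21 log units; within the scatter) from compound 3 to compound 4, 2.2-fold (0.35 log units) apart, within the scatter of two such steps. This shows no sign that the two cores respond differently to the change, but it does not prove that they respond alike, nor does it show that the amino group has any real effect on either core.

Going by these compounds, it remains open whether a larger group at the same place, such as a dimethylamino or methoxy group, would produce a step beyond the scatter.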